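Aryl hydrazone variation at the imine carbon

This account rests on a few compounds, and the source may have more. Where it says the series, first, only, none or still open, it means among the compounds named here.

Compound 2 `CN(C)c1ccc(/C=N/NC(=O)CCN2CCN(c3ccnc4cc(Cl)ccc34)CC2)cc1` stands at the top of the measured range in an ADME assay on cells (Splenocyte, Mus musculus, strain BALB/c) for cytotoxicity, read by thymidine incorporation, with a stated time of 24 h; on this read-out higher numbers stand for weaker inhibition and lower numbers for stronger inhibition: compound 2 gives > 100000 nM, a limit of the assay rather than a number, namely (the limit of > 100000 nM in this assay, at which 1 of the 2 values shown sits). Compound 1 `O=C(CCN1CCN(c2ccnc3cc(Cl)ccc23)CC1)N/N=C/c1ccccc1O` gives 11500 nM in this assay. For the measured compounds named here, the single measured step, an at least 8.6-fold higher number from compound 1 to compound 2 (0.93 log units; beyond the scatter), lies beyond the scatter. Compound 3 `O=C(CCN1CCN(c2ccnc3cc(Cl)ccc23)CC1)N/N=C/c1cccc(Cl)c1` differs from compound 2 by 3-chlorophenyl in place of 4-(dimethylamino)phenyl on a carbon with a double bond to nitrogen. Going by the values given here, only that one step bears on the change, and it runs toward the limit; moving away from 4-(dimethylamino)phenyl is expected to reverse part of it. The expected step is an at least 2.5-fold lower number from compound 2 to compound 3 (0.39 log units; beyond the scatter). For compound 3 the estimate in this assay is 40000 nM, with a range of 12000 nM to 130000 nM.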

Compound 3, half-maximal inhibitory concentration: > 100000 nM
Compound 3: only a limit was reported; the forecaster's own chance of this, stated with the estimate: 35%; at least 2.5-fold (0.39 log units) between middle value and limit.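

In this assay compound 3 gives > 100000 nM, a limit of the assay and not a number. The change from 2-hydroxyphenyl to 3-chlorophenyl gives an at least 8.6-fold higher number from compound 1 to compound 3 (0.93 log units; beyond the scatter), so a step of this kind on the carbon with a double bond to nitrogen is not confined to 4-(dimethylamino)phenyl. The step between the two compounds at the limit cannot be read, and the limit now holds most of the series: the limit of > 100000 nM in this assay, at which 2 of the 3 values shown sit.

As far as these compounds go, only compound 1 gives a number, and whether this depends on the hydroxyl group itself or on its placement remains open. A 4-hydroxyphenyl or 2-aminophenyl group on this carbon would bear on that question.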